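Amide tail truncation in a spiro series: compound 4 outlook

The source may report more compounds than this note shows. Statements on the series, on what has been measured and on what is new or still open speak of the compounds shown alone.

Compound 1 `CC(C)(C)c1ccc(C(=O)N2CCC3(CC2)C(=O)N(CC(=O)N2CCC(CCO)CC2)CN3c2ccccc2)cc1`: 2600 nM
Compound 2 `CC(C)(C)OC(=O)NCCNC(=O)CN1CN(c2ccccc2)C2(CCN(C(=O)c3ccc(C(C)(C)C)cc3)CC2)C1=O`: 10900 nM
Compound 3 `CC(C)(C)OC(=O)NCCCNC(=O)CN1CN(c2ccccc2)C2(CCN(C(=O)c3ccc(C(C)(C)C)cc3)CC2)C1=O`: 4500 nM

In an assay on HEK293 cells for displacement of a labelled ligand from NPC1-like intracellular cholesterol transporter 1 (Homo sapiens) (a higher number here means a weaker inhibitor, a lower number a stronger inhibitor), compound 3 gives 4500 nM, the second highest of the three numbers; the gap a 1.7-fold higher number from compound 1 to compound 3 (0.24 log units; within the scatter) is within the scatter, while a 2.4-fold lower number from compound 2 to compound 3 (0.38 log units; beyond the scatter) is beyond it. Compound 4 `CC(C)(C)c1ccc(C(=O)N2CCC3(CC2)C(=O)N(CC(=O)NCCO)CN3c2ccccc2)cc1` arises from compound 3 by hydroxy in place of ((tert-butoxycarbonyl)amino)methyl on a saturated chain carbon, two bonds along the chain from an amide-type nitrogen. Going by the values given here, no measured step introduces hydroxy on this tail. Among the compounds with values here, the steps that bear on it are a 2.4-fold lower number from compound 2 to compound 3 (0.38 log units; beyond the scatter), where the shorter tail carried the higher number, and a 4.2-fold higher number from compound 1 to compound 2 (0.62 log units; beyond the scatter), where that same shorter tail read higher than the hydroxyethyl piperidine tail. Compound 4 has a short tail ending in hydroxy, so a modest rise is expected, a 1.6-fold higher number from compound 3 to compound 4 (0.19 log units; within the scatter). Compound 4 is estimated at 7000 nM, with a range of 2500 nM to 18000 nM.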

Compound 4, half-maximal inhibitory concentration: 1000 nM
Compound 4: the middle estimate sits 7.0-fold (0.85 log units) above what was measured, and the stated range ends above it.
By their numbers in this assay, from the lowest: compound 4; then compounds 1 and 3 (each within the scatter of the next); then compound 2.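

In this assay, hydroxy on this saturated chain carbon, two bonds along the chain from an amide-type nitrogen, gives the lowest number of the series (a 4.5-fold lower number from compound 3 to compound 4 (0.65 log units; beyond the scatter); an 11-fold lower number from compound 2 to compound 4 (1.04 log units; beyond the scatter)), so a short tail is compatible with the lowest number, and the high number of compound 2 does not follow from tail length alone. The open (2-hydroxyethyl)amino tail also reads lower than the 4-(2-hydroxyethyl)piperidin-1-yl tail (a 2.6-fold lower number from compound 1 to compound 4 (0.41 log units; beyond the scatter)). No evidence explains these shifts.

Still open, as far as these compounds go, is whether the hydroxy end itself matters. An amine, a carboxylic acid or a methoxy at this carbon, or a longer chain ending in hydroxy, would separate the end group from chain length.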